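Compound 3, a stereo partner of compound 2

The source may hold more compounds than are shown below. What is called first, only, known or untested is meant among the compounds shown, and "the series" means these compounds.

Compound 1 `C/C=C/[C@H]1C/C=C\C[C@@H](Cl)[C@@H](C[C@@H](O)C=C=CBr)O1`: > 10 ug/mL, a limit
Compound 2 `C/C=C/[C@H]1C/C=C\C[C@@H](Cl)[C@@H](C[C@H](C=C=CBr)OC(C)=O)O1`: > 10 ug/mL, a limit

In a functional assay on HBL-100 cells (Homo sapiens) for antiproliferative activity, with a stated time of 48 h (on this read-out higher numbers stand for weaker inhibition of growth and lower numbers for stronger inhibition of growth), compound 2 gives > 10 ug/mL, which is a limit and not a number. The picture so far is the limit of > 10 ug/mL in this assay, at which 2 of the 2 values shown sit. Compound 3 `C/C=C/[C@H]1C/C=C\C[C@@H](Cl)[C@@H](C[C@@H](C=C=CBr)OC(C)=O)O1` differs from compound 2 as follows: the two compounds have the same atoms and bonds; at least one stereo element is drawn with a configuration in one of them and without one in the other: 1 of 8 stereo elements differ; a stereocentre at a saturated chain carbon is drawn R in compound 2 and S in compound 3. For the measured compounds named here, the only measured step, a step that the two limits leave unreadable from compound 1 to compound 2, concerns an acetyl group and has no readable size, so it gives no measure for a stereo change. No step beyond the scatter is therefore expected, and no direction. The expected step is a step that the limit leaves unreadable from compound 2 to compound 3. Compound 3 is estimated at 12 ug/mL, with an expected range from 5 ug/mL to 25 ug/mL.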

Compound 3, concentration for 50% growth inhibition: > 10 ug/mL
Compound 3: no number, only a limit; the forecaster's own chance of this, stated with the estimate: 70%; the middle value is on the limit's open side.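

In this assay no step can be read between compound 2 and compound 3, as each gives only a limit: the limit of > 10 ug/mL in this assay, at which 3 of the 3 values shown sit. The compounds shown leave open whether the configuration at the saturated chain carbon affects growth inhibition at all.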